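The source may hold more compounds than are shown below. What is called first, only, known or untested is meant among the compounds shown, and "the series" means these compounds.

Measured so far:
compound 1, `CC1(C)Cc2c(sc(NC(=O)c3ccccc3O)c2C(N)=O)C(C)(C)O1`: 162 nM
compound 2, `CC(C)(C)CC(O)C(=O)Nc1sc2c(c1C(N)=O)CC(C)(C)OC2(C)C`: 981 nM

Both values come from an assay on cells for positive allosteric modulation of Cystic fibrosis transmembrane conductance regulator variant G551D (Homo sapiens), with stated times of 10 min and 2 min, in the presence of a further agent that is not named here; a lower number here means that less compound is needed, a higher number that more compound is needed for the effect. Within the data shown here, compound 2 stands at the higher of the two numbers, with compound 1 as its only neighbour: the step of a 6.1-fold higher number from compound 1 to compound 2 (0.78 log units; beyond the scatter) is the one measured change, and it went against compound 2.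

Compound 3, `CC1(C)Cc2c(sc(NC(=O)c3[nH]ncc3Cl)c2C(N)=O)C(C)(C)O1`, has not yet been measured in this assay. It differs from compound 2 in one place: a group of 6 heavy atoms (3 carbon, 2 nitrogen, 1 chlorine; one five-membered aromatic ring with 2 hetero atoms) in place of a group of 7 heavy atoms (6 carbon, 1 oxygen; no ring), on a carbonyl carbon. Thus the change at the carbonyl carbon once more exchanges an open chain for an aromatic ring, and in this way it reverses the direction of the only measured step. That step, a 6.1-fold higher number from compound 1 to compound 2 (0.78 log units; beyond the scatter), showed that the open chain was worse than an aromatic ring in this assay. Compound 3 carries a different ring, a smaller one with two hetero atoms, so the earlier step is a guide and not a rule.

On this basis a lower number for compound 3 than for compound 2 is expected, with the step estimated as a 3.9-fold lower number from compound 2 to compound 3 (0.59 log units; beyond the scatter). The estimate for compound 3 in this assay is 250 nM, with a range from 80 nM to 800 nM.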

Compound 3, half-maximal effective concentration: 81 nM
For compound 3 the middle estimate is 3.1-fold (0.49 log units) above the measured one; the measured number falls inside the stated range.
By their numbers in this assay, from the lowest: compounds 3 and 1 (each within the scatter of the next); then compound 2.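

In this assay the open chain on the carbonyl carbon now falls short of two different aromatic rings rather than one, and the exchange for the five-membered aromatic ring with 2 hetero atoms gives a large step (a 12-fold lower number from compound 2 to compound 3 (1.08 log units; beyond the scatter)). The two rings themselves cannot be told apart (a 2.0-fold lower number from compound 1 to compound 3 (0.30 log units; within the scatter)), so at this position a six-membered aromatic ring of carbon only and a five-membered ring containing nitrogen and chlorine serve about equally well, even though their atoms differ. Nothing measured here gives a reason for the gap between the chain and the rings.

Only one open chain is shown, so it remains open whether an aromatic ring is needed at all, or whether a longer chain, or a chain ending in an amine or a carboxylic acid, would do as well on the same carbonyl carbon. Also open, going by these compounds, is what the chlorine contributes, since the same five-membered ring with a hydrogen or a methyl group in place of chlorine would be needed to separate its share from that of the ring itself.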